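The source may hold more compounds than are shown below. What is called first, only, known or untested is meant among the compounds shown, and "the series" means these compounds.

Measured so far:
compound 1 `O=C1C=CC2(C=C1)OCC(=O)N2c1nc(-c2ccc3ccccc3c2Br)nn1-c1ccccc1` gives 50 nM
compound 2 `CC1OC2(C=CC(=O)C=C2)N(c2nc(-c3cccc4ccccc34)nn2-c2ccccc2)C1=O` gives 100 nM
compound 3 `Cc1ccc(-n2nc(-c3ccc4ccccc4c3)nc2N2C(=O)C(C)OC23C=CC(=O)C=C3)cc1` gives 100 nM

In a functional assay on MDA-MB-231 cells (Homo sapiens) for antiproliferative activity, with a stated time of 5 days (a lower number here means a stronger inhibitor, a higher number a weaker inhibitor), compound 3 sits level with compound 2 at the digits shown, the two together the highest of the three numbers; compound 1 lies a step away that stays within the scatter, so the three values cannot be ranked against each other.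

Compound 4 `CC1OC2(C=CC(=O)C=C2)N(c2nc(-c3ccc4ccccc4c3)nn2-c2ccc3ccccc3c2)C1=O` has not been measured. It differs from compound 3 in one place: naphthalen-2-yl in place of 4-methylphenyl on an aromatic nitrogen. No measured pair shows this exchange, and compound 2 and compound 3 return the same number at the digits shown, so nothing here points to a gain or a loss. The step of no change at the digits printed from compound 3 to compound 4 (within the scatter) is therefore expected to stay within the scatter, with no direction preferred.

Compound 4 is expected at 100 nM, in the range 40 nM to 250 nM.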

Compound 4, half-maximal inhibitory concentration: 60 nM
Compound 4: middle estimate off by 1.7-fold (0.22 log units), on the high side; measured number inside the range.
By their numbers in this assay, from the lowest: compounds 1, 4, 2 and 3 (each within the scatter of the next).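

In this assay, going by these compounds alone, naphthalen-2-yl in place of 4-methylphenyl on the aromatic nitrogen gives a 1.7-fold lower number from compound 3 to compound 4 (0.22 log units; within the scatter), the only direct reading of an exchange at this position. The larger group, with two six-membered aromatic rings of carbon only instead of one, therefore brings no change beyond the scatter. No measurement available here bears on the size of this step.

Only aromatic groups of carbon alone are compared at this position. On these data alone, whether an amine, a carboxylic acid or a longer alkyl chain there would move the number beyond the scatter remains open.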